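The source may hold more compounds than are shown below. What is called first, only, known or untested is meant among the compounds shown, and "the series" means these compounds.

Of the compounds shown here, three have been measured in a physicochemical assay for solubility, read by spectrophotometry, measured as kinetic solubility, at pH 8, tested at 500 uM; on this read-out lower numbers stand for lower solubility and higher numbers for higher solubility. Compound 1 `Cn1ccc2ccc(-c3cc(Nc4ccccc4S(N)(=O)=O)cc4nccnc34)cc21` gives 6 ug/mL. Within the data shown here, compound 2 `CN1CCC(NS(=O)(=O)c2ccccc2Nc2cc(-c3ccc4ccn(C)c4c3)c3nccnc3c2)C1`, which carries a 1-methylpyrrolidin-3-yl group on its sulfonamide nitrogen, gives 26 ug/mL, and that single change is the only measured step: a 4.3-fold higher number from compound 1 to compound 2 (0.64 log units; beyond the scatter). Among the measured compounds shown here, compound 3 `CN1CCC(NC(=O)c2ccncc2Nc2cc(-c3ccc4ccn(C)c4c3)c3nccnc3c2)CC1` gives 246 ug/mL, the highest of the three numbers; it is beyond the scatter above compound 2 and far above compound 1, although no single step links it to either.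

Compound 4 `CC(=O)N1CC(NC(=O)c2ccncc2Nc2cc(-c3ccc4ccn(C)c4c3)c3nccnc3c2)C1` is the next candidate. It differs from compound 3 in one place: 1-acetylazetidin-3-yl in place of 1-methylpiperidin-4-yl on an amide-type nitrogen. For the measured compounds named here, no measured step covers this exact swap. The step from compound 1 to compound 2 is the nearest guide, and it showed that adding a small nitrogen-containing ring at a nitrogen of this kind moved solubility by a modest amount; here, one such ring is exchanged for another, so a move of similar size, in either direction, is plausible. Compound 4 is estimated at 70 ug/mL, within a range of 20 ug/mL to 200 ug/mL, which would mean an expected step of a 3.5-fold lower number from compound 3 to compound 4 (0.55 log units; beyond the scatter) in this assay.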

Compound 4, solubility: 244 ug/mL
For compound 4 the middle estimate is 3.5-fold (0.54 log units) below the measured one, outside the stated range (above it).
By their numbers in this assay, from the lowest: compound 1; then compound 2; then compounds 4 and 3 (each within the scatter of the next).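

In this assay, putting 1-acetylazetidin-3-yl in place of 1-methylpiperidin-4-yl on an amide-type nitrogen gives a 1.0-fold lower number from compound 3 to compound 4 (0.00 log units; within the scatter). Among these compounds, until now this nitrogen had been seen with only one group, whereas this pair shows that a six-membered ring with a methyl group and a four-membered ring with an acetyl group cannot be told apart in this read-out, even though only the acetyl group brings an oxygen and a double bond outside aromatic rings. Nothing measured here explains why these two different groups read alike.

The compounds shown leave open whether other groups on this nitrogen would also fall within the scatter of compound 3 and compound 4, such as an open chain ending in a dimethylamino group, a chain ending in a carboxylic acid, or a plain hydrogen. The plain hydrogen would be especially informative, since it would show how much either ring contributes to the solubility reading in the first place.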